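Replacing the Imidazole Arm with an Amide

The source may report more compounds than this note shows. Statements on the series, on what has been measured and on what is new or still open speak of the compounds shown alone.

Compound 1 `CC(C)C(Cc1ncc[nH]1)c1ccc(-c2ccc3cccc(F)c3c2)[nH]c1=O`: 11 nM
Compound 2 `CC(C)C(Nc1nnc[nH]1)c1ccc(-c2ccc3cccc(F)c3c2)[nH]c1=O`: 22 nM
Compound 3 `CC(C)C(Cc1nnn[nH]1)c1ccc(-c2ccc3cccc(F)c3c2)[nH]c1=O`: 34 nM

In an assay on CHO cells for displacement of a labelled ligand from prostaglandin E2 receptor EP3 subtype (Homo sapiens), read by radioligand binding (on this read-out higher numbers stand for weaker inhibition and lower numbers for stronger inhibition), compound 1 gives the lowest of the three numbers. Compound 4 `CC(C)NC(=O)CC(c1ccc(-c2ccc3cccc(F)c3c2)[nH]c1=O)C(C)C` differs from it in one place: isopropylcarbamoyl in place of 1H-imidazol-2-yl on a saturated chain carbon, two bonds along the chain from an aromatic carbon. Within the data shown here, two measured steps touch the same position. Exchanging the ring for another five-membered aromatic ring gave a 2.0-fold higher number from compound 1 to compound 2 (0.30 log units; within the scatter) and a 3.1-fold higher number from compound 1 to compound 3 (0.49 log units; beyond the scatter), so every change at this arm so far has raised the number, modestly at most. Among the measured compounds shown here, an open-chain amide is a larger departure than either, and no measured compound shows what that costs. Compound 4 is therefore expected to show a 3.6-fold higher number from compound 1 to compound 4 (0.56 log units; beyond the scatter), a weaker result than compound 1. The estimate for compound 4 is 40 nM, ranging from 10 nM to 160 nM.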

Compound 4, inhibition constant: 5.8 nM
Beside the measured number, compound 4's estimate is 6.9-fold (0.84 log units) above it; measured number outside the range, below it.
By their numbers in this assay, from the lowest: compounds 4, 1, 2 and 3 (each within the scatter of the next, the first and the last beyond it).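

The step of a 1.9-fold lower number from compound 1 to compound 4 (0.28 log units; within the scatter) shows that a five-membered aromatic ring is not needed on this chain carbon: isopropylcarbamoyl, which has no ring, serves as well as 1H-imidazol-2-yl. The same amide also clearly outperforms the other two arms, with a 5.9-fold lower number from compound 3 to compound 4 (0.77 log units; beyond the scatter) and a 3.8-fold lower number from compound 2 to compound 4 (0.58 log units; beyond the scatter) as the steps. Still open, from the compounds shown here alone, is whether a smaller methylcarbamoyl group, a carboxylic acid or a longer chain on the amide nitrogen would hold this level. Nothing shown explains why the amide is tolerated here.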